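Methyl in place of nitro on an enol series

A few compounds are considered here, and "the series" means these few. Any claim that something is new, unique, unknown or untested is made for them only; others in the source may bear on it.

Compound 3 `O=C(/C=C(O)/C=C/c1ccc([N+](=O)[O-])cc1)c1ccccc1O` was tested in an in vitro assay on cells for inhibition of Amine oxidase [flavin-containing] A (Homo sapiens), read by Amplex Red, with a stated time of 15 min, tested at 100 uM; on this read-out lower numbers stand for less inhibition and higher numbers for more inhibition at the one concentration tested (going by the name of the read-out). In this assay compound 3 is reported as "not active" (no number reported), with no number given, so it stands without a value that could be set against the others; one further compound shares this outcome. That compound is compound 1 `COc1ccc(/C=C/C=C/C(=O)c2cc(Cl)ccc2O)cc1`, which in this assay is likewise reported as "not active" (no number reported) without a number. Compound 2 `COc1ccc(/C=C/C=C/C(=O)c2ccccc2O)cc1` does give a value, and in this assay compound 2 shows 40%. Compound 4 `Cc1ccc(/C=C/C(O)=C/C(=O)c2ccccc2O)cc1` has not yet been measured. It differs from compound 3 by methyl in place of nitro on an aromatic carbon, the change sitting on an aromatic carbon of a six-membered aromatic ring of carbon only, para to a large group. Going by the values given here, no step between measured compounds is available, so the size of this change cannot be read from any measured pair. Among the compounds with values here, compound 3 is reported inactive, and nothing among the measured compounds shows that this change brings a rise beyond the scatter. Compound 4 is therefore expected to give about 15% in this assay, within a range from 0% to 40%, with a fair chance that it too is reported only as not active.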

Compound 4, a percentage reported as inhibition, at one concentration (the size of the read-out at that concentration, not a potency): "not active" (no number reported)
Nothing numeric was reported for compound 4, so the estimate cannot be set against anything.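

Compound 3 and compound 4 both stand without a number in this assay, so no step can be read between them. The compounds shown leave open how far methyl in place of nitro shifts inhibition. No further data bear on this result.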